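The source may hold more compounds than are shown below. What is called first, only, known or untested is meant among the compounds shown, and "the series" means these compounds.

In an assay for inhibition of Catechol O-methyltransferase (Rattus norvegicus), read by fluorescence and spectrophotometry (on this read-out higher numbers stand for weaker inhibition and lower numbers for stronger inhibition), compound 1 `CC(=O)N1N=C(c2cc(O)c(O)c([N+](=O)[O-])c2)CC1c1ccco1` gives 180 nM. Compound 2 `O=C(/C=C/c1cccc(O)c1)c1cc(O)c(O)c([N+](=O)[O-])c1` gives 140 nM, and compound 3 `O=C(/C=C/c1cccs1)c1cc(O)c(O)c([N+](=O)[O-])c1` gives 190 nM. Compound 1 thus holds the second highest of the three numbers, though its gaps to compound 3 and to compound 2 are both within the scatter. The unmeasured compound 4 `CC(=O)N1N=C(c2cc(O)c(O)c([N+](=O)[O-])c2)CC1c1cccc(C#N)c1` differs from compound 1 in one place: 3-cyanophenyl in place of furan-2-yl on a saturated ring carbon. Among the compounds with values here, only one measured step concerns an exchange of one aromatic ring for another, and there the exchange sits on a double-bonded chain carbon, not on a saturated ring carbon of the shared core of compound 1: a 1.4-fold higher number from compound 2 to compound 3 (0.13 log units; within the scatter). Within the data shown here, that step stayed within the scatter, and no measured pair shows what a 3-cyanophenyl group does on this core. The expectation for this assay is therefore a step of no clear size beyond the scatter, a 1.1-fold lower number from compound 1 to compound 4 (0.02 log units; within the scatter), in either direction. Compound 4 is estimated at 170 nM, with a range from 60 nM to 500 nM.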

Compound 4, half-maximal inhibitory concentration: 79 nM
For compound 4 the middle estimate is 2.2-fold (0.33 log units) above the measured one, within the range that was stated.
By their numbers in this assay, from the lowest: compounds 4, 2, 1 and 3 (each within the scatter of the next, the first and the last beyond it).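

In this assay, 3-cyanophenyl in place of furan-2-yl on a saturated ring carbon gives a 2.3-fold lower number from compound 1 to compound 4 (0.36 log units; beyond the scatter), so the number at this position of the shared core does respond to the ring it carries, and a six-membered aromatic ring bearing a nitrile is accepted here with no loss. Within the data shown here, the only earlier exchange of one aromatic ring for another, on a double-bonded chain carbon and on a different scaffold, gave a 1.4-fold higher number from compound 2 to compound 3 (0.13 log units; within the scatter) and did not show a change of this kind. No measurement at hand explains why the number moves at this position.

Open, going by these compounds, is whether a plain phenyl ring would give the same number, and so how much of the step belongs to the ring and how much to the nitrile. Also open, on these data alone, is what a carboxylic acid or an amine would do in place of the nitrile.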